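A Shared Amide Change Tested on a Second Core

The compounds below may be only part of what the source reports. "The series", "measured", "known", "first", "only" and "open" are said of these compounds alone.

Compound 1 `CC[C@@H](C)[C@H](NC(=O)c1ccc(C(CC)(CC)c2ccc(OCC(=O)C(C)(C)C)c(C)c2)n1CC)C(=O)O` and compound 3 `CC[C@@H](C)[C@H](NC(=O)c1ccc(C(CC)(CC)c2ccc(OCC(O)C(C)(C)C)c(C)c2)n1CC)C(=O)O` share most of their structure; their cores differ by 1-hydroxy-2,2-dimethylpropyl in place of (tert-butyl)carbonyl on a saturated chain carbon bound to an oxygen on an aromatic ring. In a functional assay on MCF7 cells (Homo sapiens), read by MTT assay, with a stated time of 48 h (on this read-out lower numbers stand for stronger inhibition and higher numbers for weaker inhibition), compound 1 gives 160 nM, and compound 3 gives 2000 nM, a step of a 13-fold higher number from compound 1 to compound 3 (1.10 log units; beyond the scatter). Compound 2 `CCn1c(C(=O)N(C)CC(=O)O)ccc1C(CC)(CC)c1ccc(OCC(=O)C(C)(C)C)c(C)c1` is derived from compound 1 by (carboxymethyl)(methyl)amino in place of (1-carboxy-2-methylbutyl)amino on a carbonyl carbon, and in this assay compound 2 gives 28600 nM, so that a 180-fold higher number from compound 1 to compound 2 (2.25 log units; beyond the scatter). Compound 4 `CCn1c(C(=O)N(C)CC(=O)O)ccc1C(CC)(CC)c1ccc(OCC(O)C(C)(C)C)c(C)c1` carries the same change made from compound 3, namely ((carboxymethyl)(methyl)amino in place of (1-carboxy-2-methylbutyl)amino on a carbonyl carbon), at a place described in the same words in both cases. Since the step of a 180-fold higher number from compound 1 to compound 2 (2.25 log units; beyond the scatter) was large, and compound 3 already starts from 2000 nM, the number for compound 4 in this assay is expected to rise by about a 130-fold higher number from compound 3 to compound 4 (2.10 log units; beyond the scatter). Compound 4 is therefore estimated at roughly 250000 nM, between 50000 nM and 1000000 nM, though so weak a number may well be reported only as a limit.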

Compound 4, half-maximal inhibitory concentration: 25400 nM
Compound 4: the middle estimate sits 9.8-fold (0.99 log units) above what was measured; measured number outside the range, below it.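

On the second core, the amide change still gives a 13-fold higher number from compound 3 to compound 4 (1.10 log units; beyond the scatter), so its direction holds in this assay but its size does not: the same change on two cores in this assay, a 180-fold higher number (2.25 log units; beyond the scatter) from compound 1 to compound 2 and a 13-fold higher number (1.10 log units; beyond the scatter) from compound 3 to compound 4, 14-fold (1.15 log units) apart, beyond the scatter of two such steps. Read the other way, 1-hydroxy-2,2-dimethylpropyl in place of (tert-butyl)carbonyl, a large step on the first core, gives a 1.1-fold lower number from compound 2 to compound 4 (0.05 log units; within the scatter) on the second: the same change on two cores in this assay, a 13-fold higher number (1.10 log units; beyond the scatter) from compound 1 to compound 3 and a 1.1-fold lower number (0.05 log units; within the scatter) from compound 2 to compound 4, 14-fold (1.15 log units) apart, beyond the scatter of two such steps. The two changes therefore do not add up independently in these four compounds, but this single pair of cores shows neither why that is nor whether it would hold on any other core.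

Still open, going by these compounds, is how (carboxymethyl)amino, without the methyl on its nitrogen, would compare on either core. So too is how a longer amino acid chain ending in a carboxylic acid would behave on the carbonyl carbon.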